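The source may hold more compounds than are shown below. What is called first, only, known or untested is meant among the compounds shown, and "the series" means these compounds.

Compound 1 `CCOC(=O)c1c(-c2cc(F)cc(OC)c2)[nH]c2cc(OC)ccc2c1=O` and compound 2 `CCOC(=O)c1c(-c2cccc(OC(C)C)c2)[nH]c2cc(OC)ccc2c1=O` share one core. In an ADME assay on HEK293 cells (Homo sapiens) for cytotoxicity, read by luminescence, with a stated time of 72 h (a lower number here means that less compound is needed, a higher number that more compound is needed for the effect), compound 1 gives only a limit, > 22000 nM. In this assay compound 2 likewise gives only a limit, > 22000 nM. Compound 2 therefore sits together with the other value shown at the limit of > 22000 nM in this assay, at which 2 of the 2 values shown sit. Compound 3 `CCOC(=O)c1c(-c2cccc(C(F)(F)F)c2)[nH]c2cc(OC)ccc2c1=O` carries trifluoromethyl in place of isopropoxy on an aromatic carbon. Within the data shown here, no step between two measured compounds is known for this change, so in this assay no step beyond the scatter is expected in either direction. Compound 3 is expected to remain at the limit, with an estimated value around 30000 nM in the range 15000 nM to 60000 nM. The expected step that the limit leaves unreadable from compound 2 to compound 3 is thus none beyond the scatter.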

Compound 3, half-maximal effective concentration: > 22000 nM
Compound 3: no number, only a limit; the forecaster's own chance of this, stated with the estimate: 80%; the middle value lies beyond the limit too.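

Compound 2 and compound 3 each give only a limit in this assay; no step can be read for trifluoromethyl in place of isopropoxy. The compounds shown leave open at what concentration any of them would reach the half-maximal effect in this assay.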